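Pyridinyloxy in Place of Aminopiperidinyl on the Shared Core

The source may hold more compounds than are shown below. What is called first, only, known or untested is meant among the compounds shown, and "the series" means these compounds.

Measured compounds:
compound 1 `Cc1cc(Sc2ccccc2Cl)c(S(C)(=O)=O)cc1C(=O)N=C(N)N` — 14 nM
compound 2 `Cc1cc(Sc2ccc(Cl)cc2)c(S(C)(=O)=O)cc1C(=O)N=C(N)N` — 19 nM
compound 3 `Cc1cc(N2CCC(N)CC2)c(S(C)(=O)=O)cc1C(=O)N=C(N)N` — 9.8 nM

In a functional assay for inhibition of sodium/hydrogen exchanger (Oryctolagus cuniculus) (a higher number here means a weaker inhibitor, a lower number a stronger inhibitor), compound 3 holds the lowest of the three numbers, but all three lie close together: a 1.4-fold lower number from compound 1 to compound 3 (0.15 log units; within the scatter), a 1.9-fold lower number from compound 2 to compound 3 (0.29 log units; within the scatter) and a 1.4-fold higher number from compound 1 to compound 2 (0.13 log units; within the scatter). Among the measured compounds shown here, no compound can therefore be called the strongest or weakest among them.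

Compound 4 `Cc1cc(Oc2cccnc2)c(S(C)(=O)=O)cc1C(=O)N=C(N)N` has not yet been measured. Its change from compound 3 is (pyridin-3-yl)oxy in place of 4-aminopiperidin-1-yl on an aromatic carbon. For the measured compounds named here, the steps that bear on this position are the two in which the same 4-aminopiperidin-1-yl entered in place of an arylsulfanyl group, and both stayed within the scatter. The incoming (pyridin-3-yl)oxy group is aromatic, like the groups it resembles in compound 1 and compound 2, and differs from them in the linking atom and the ring nitrogen, which is not covered by any measured step. Since neither exchange at this position moved the number beyond the scatter, compound 4 is expected to stay near the others, with at most a small rise toward the numbers of compound 1 and compound 2: the expected step is a 1.5-fold higher number from compound 3 to compound 4 (0.18 log units; within the scatter). The estimate for compound 4 in this assay is 15 nM, between 6 nM and 40 nM.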

Compound 4, half-maximal inhibitory concentration: 8.8 nM
The estimate for compound 4 lay 1.7-fold (0.23 log units) above the measured number, and the stated range covers the measured number.
By their numbers in this assay, from the lowest: compounds 4, 3, 1 and 2 (each within the scatter of the next, the first and the last beyond it).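

On this aromatic carbon of the shared core, the non-aromatic 4-aminopiperidin-1-yl group, which carries a hydrogen-bond donor, gives way to the aromatic (pyridin-3-yl)oxy group, which carries none, and this assay shows only a 1.1-fold lower number from compound 3 to compound 4 (0.05 log units; within the scatter), so in this pair neither that donor nor the non-aromatic ring is needed to keep the number this low. The same group in place of (4-chlorophenyl)sulfanyl gives a 2.2-fold lower number from compound 2 to compound 4 (0.33 log units; beyond the scatter), the first step among these compounds to pass the scatter, while in place of (2-chlorophenyl)sulfanyl it gives a 1.6-fold lower number from compound 1 to compound 4 (0.20 log units; within the scatter), so the aromatic groups on this carbon do not all read alike. No accompanying evidence bears on the reason for these small differences.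

The oxygen link and the ring nitrogen changed together, so the compounds shown leave open which of the two goes with the modest step; an unsubstituted phenoxy group and a (pyridin-3-yl)sulfanyl group would separate them. Also open, from the compounds shown here alone, is how the number responds to a pyridin-2-yl or pyridin-4-yl ring on the same oxygen, or to an open-chain aminoethylamino group in place of the piperidine.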